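Compound 3 follows a measured limit

This account rests on a few compounds, and the source may have more. Where it says the series, first, only, none or still open, it means among the compounds named here.

Measured in a physicochemical assay for metabolic stability, read by HPLC and mass spectrometry, in phosphate buffer, at 37 degrees C, at pH 7.4; on this read-out higher numbers stand for a longer-lived compound and lower numbers for a shorter-lived compound:
Compound 1 `CC(C)(O/N=C(\C(=O)N[C@@H]1C(=O)N(S(=O)(=O)O)[C@@H]1CN1CCCCC1=O)c1csc(N)n1)C(=O)O` gives 214 h
Compound 2 `CC(C)(O/N=C(\C(=O)N[C@@H]1C(=O)N(S(=O)(=O)O)[C@@H]1CN1C[C@H](CN)OC1=O)c1csc(N)n1)C(=O)O` gives > 37 h

Compound 2 stands at a limit of the assay and not at a number (> 37 h). That limit is all that is known of it (the limit of > 37 h in this assay, at which 1 of the 2 values shown sits). Going by the values given here, the one measured step (a step that the limit leaves unreadable from compound 1 to compound 2) falls at the same place, on a saturated chain carbon bound to a saturated ring carbon, but it gives no size to carry forward.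

Among the compounds with values here, compound 3 (`CC(C)(O/N=C(\C(=O)N[C@@H]1C(=O)N(S(=O)(=O)O)[C@@H]1CN1C[C@@H](CNC(=N)N)OC1=O)c1csc(N)n1)C(=O)O`) keeps the shared core and changes only this group (a group of 11 heavy atoms (5 carbon, 4 nitrogen, 2 oxygen; one five-membered non-aromatic ring with 2 hetero atoms) in place of a group of 8 heavy atoms (4 carbon, 2 nitrogen, 2 oxygen; one five-membered non-aromatic ring with 2 hetero atoms), on a saturated chain carbon bound to a saturated ring carbon). Within the data shown here, without a readable step, the expectation rests on compound 1 (214 h) as the only number available in this assay, and a long half-life is expected. The estimated step is loose (a step that the limit leaves unreadable from compound 2 to compound 3). Compound 3 is expected at 90 h, with an estimated range from 30 h to 250 h.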

Compound 3, half-life: > 37 h
Compound 3 ended at the assay's limit (the forecaster's own chance of this, stated with the estimate: 40%); the middle value is on the limit's open side.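

In this assay compound 3 gives > 37 h, which is a limit and not a number. Going by these compounds, no new step can be read among compound 1, compound 2 and compound 3: the limit of > 37 h in this assay, at which 2 of the 3 values shown sit. The true half-lives of compound 2 and compound 3, and how they compare with each other and with compound 1, remain open.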